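This account rests on a few compounds, and the source may have more. Where it says the series, first, only, none or still open, it means among the compounds named here.

Measured compounds:
compound 1 `CC1CC/C(=N\Nc2cccc(Cl)c2)c2ncc(C(=O)O)c(=O)n21` — 0.6 umol/kg
compound 2 `Cc1cccc(N/N=C2\CCC(C)n3c2ncc(C(=O)O)c3=O)c1` — 0.4 umol/kg
compound 3 `Cc1ccc(N/N=C2\CCC(C)n3c2ncc(C(=O)O)c3=O)cc1` — 1.3 umol/kg

In a functional assay on the whole organism for inhibition, with Rattus norvegicus as the target (a lower number here means that less compound is needed, a higher number that more compound is needed for the effect), compound 3 stands highest of the three: the steps of a 2.2-fold higher number from compound 1 to compound 3 (0.34 log units; beyond the scatter) and a 3.3-fold higher number from compound 2 to compound 3 (0.51 log units; beyond the scatter) both lie beyond the scatter, whereas a 1.5-fold lower number from compound 1 to compound 2 (0.18 log units; within the scatter) does not. Compound 4 `CC1CC/C(=N\Nc2ccc(C3CC3)cc2)c2ncc(C(=O)O)c(=O)n21` differs from compound 3 by cyclopropyl in place of methyl on an aromatic carbon. Within the data shown here, no measured step exchanges one group for another at this place with the rest of the molecule held fixed, so nothing measured bears directly on the change; the steps into compound 3 show only that what sits on this ring moves the number modestly. The expectation is therefore a step of a 1.2-fold higher number from compound 3 to compound 4 (0.06 log units; within the scatter) not beyond the scatter. The estimate for compound 4 is 1.5 umol/kg, with a range from 0.6 umol/kg to 4 umol/kg.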

Compound 4, dose for 50% inhibition: 41.1 umol/kg
Estimate against measurement, compound 4: 27-fold (1.44 log units) below; measured number above the stated range.
By their numbers in this assay, from the lowest: compounds 2 and 1 (each within the scatter of the next); then compound 3; then compound 4.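

In this assay, cyclopropyl in place of methyl on an aromatic carbon para to a large group gives a 32-fold higher number from compound 3 to compound 4 (1.50 log units; beyond the scatter), so this position is far more sensitive than the modest steps among compound 1, compound 2 and compound 3 indicated. Neither group carries a hydrogen-bond donor, a hydrogen-bond acceptor or a net charge, so the large step comes with no change in those counts. Nothing shown accounts for its size.

As far as these compounds go, whether the three-membered ring itself or the added carbons drive the step stays open. An ethyl or isopropyl group at this place could separate the two, and an amine there would test a different kind of group.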